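Chloro to Bromo on the Aryl Oxime Series

This account rests on a few compounds, and the source may have more. Where it says the series, first, only, none or still open, it means among the compounds named here.

The series rests on two cores. Compound 1 `COc1ccc(C(/C=C/c2ccc(Cl)cc2)=N/O)cc1` and compound 2 `COc1ccc(C(/C=C/c2ccc(Br)cc2)=N/O)cc1` share one, and in a functional assay (Mus musculus, strain Balb/c) for inhibition, read by ELISA, with a stated time of 72 h (a higher number here means a weaker inhibitor, a lower number a stronger inhibitor), compound 1 gives 11500 nM, while compound 2 gives 13900 nM. For the measured compounds named here, the single change between them is bromo in place of chloro on an aromatic carbon and the step it made is a 1.2-fold higher number from compound 1 to compound 2 (0.08 log units; within the scatter).

Compound 3 `O/N=C(\C=C\c1cccs1)c1ccc(Cl)cc1` carries the other core; the difference between the two cores is not broken down here. In this assay compound 3 gives 9590 nM. Its value, compound 1's and compound 2's all lie within the usual scatter of one another, so no order among them can be read from these three numbers.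

Compound 4 `O/N=C(\C=C\c1cccs1)c1ccc(Br)cc1` is not yet measured. It differs from compound 3 by bromo in place of chloro on an aromatic carbon, the same change, at the same kind of place, that took compound 1 to compound 2. Among the compounds shown the change occurs twice in all, once measured and once not. Going by the values given here, the one measured instance, the step of a 1.2-fold higher number from compound 1 to compound 2 (0.08 log units; within the scatter), stayed within the scatter, and that is the only ground available for an expectation. Resting on compound 3 at 9590 nM and on that earlier step, the step expected from compound 3 to compound 4 in this assay is a 1.2-fold higher number from compound 3 to compound 4 (0.08 log units; within the scatter). The value estimated for compound 4 is therefore 11500 nM, with a range expected between 6000 nM and 22000 nM.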

Compound 4, half-maximal inhibitory concentration: 11200 nM
Beside the measured number, compound 4's estimate is 1.0-fold (0.01 log units) above it; the range from low to high includes it.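

In this assay, bromo in place of chloro on the core of compound 3 gave a 1.2-fold higher number from compound 3 to compound 4 (0.07 log units; within the scatter), and the two instances of this change agree: the same change on two cores in this assay, a 1.2-fold higher number (0.08 log units; within the scatter) from compound 1 to compound 2 and a 1.2-fold higher number (0.07 log units; within the scatter) from compound 3 to compound 4, 1.0-fold (0.01 log units) apart, within the scatter of two such steps. Within this series, then, the exchange behaved alike on both cores, and on neither did it produce a step that stands clear of the scatter. This does not show that bromo and chloro are equivalent in general or that the agreement would hold on a third core, and as neither step can be told from the scatter, the match is one between two null results rather than a shared measurable effect carried from one core to the other.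

The compounds shown leave open whether any substituent at this place can move the number beyond the scatter, as only chloro and bromo appear there, and a nitrile, an amine or a carboxylic acid in their stead would test this on either core. They also leave open what the oxime contributes, as every compound carries it and none has a ketone or an oxime methyl ether in its place.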